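Swapping the Aryl Cap of a Sulfonamide Peptidomimetic

A few compounds are considered here, and "the series" means these few. Any claim that something is new, unique, unknown or untested is made for them only; others in the source may bear on it.

Two compounds sharing one core have been examined in an ADME assay on HepG2 cells (Homo sapiens) for cytotoxicity; on this read-out higher numbers stand for an effect only at larger amounts of compound and lower numbers for an effect already at smaller amounts. Compound 1 `Cc1ccc(S(=O)(=O)N[C@@H](CC(=O)NC(C)(C)C)C(=O)NCCNC(=O)c2ccccc2)cc1` reaches only the assay limit, giving > 11000 nM in this assay. Compound 2 `Cc1ccc(S(=O)(=O)N[C@@H](CC(=O)NC(C)(C)C)C(=O)NCCNC(=O)c2c(O)cccc2F)cc1` likewise stops at the limit, with > 11000 nM in this assay. The step that the two limits leave unreadable from compound 1 to compound 2 cannot be sized, since both readings rest on (the limit of > 11000 nM in this assay, at which 2 of the 2 values shown sit). For the measured compounds named here, compound 2 thus stands at the limit, beside the one other value shown, which is a limit too. Compound 3 `C#Cc1cccc(C(=O)NCCNC(=O)[C@H](CC(=O)NC(C)(C)C)NS(=O)(=O)c2ccc(C)cc2)c1` is not yet measured; it differs from compound 2 by 3-ethynylphenyl in place of 2-fluoro-6-hydroxyphenyl on a carbonyl carbon. Only the unreadable step from the first pair bears on this change, so no size can be drawn from it. No step beyond the scatter is expected, and the step that the limit leaves unreadable from compound 2 to compound 3 is estimated to be small. Compound 3 is expected to give 20000 nM in this assay, within 11000 nM to 60000 nM, most likely again reported as a limit.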

Compound 3, half-maximal effective concentration: > 11000 nM
Compound 3: no number, only a limit; the forecaster's own chance of this, stated with the estimate: 85%; the middle value is on the limit's open side.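

No step can be read among compound 1, compound 2 and compound 3 in this assay, as all three readings are limits: the limit of > 11000 nM in this assay, at which 3 of the 3 values shown sit.

The compounds shown leave open whether the phenyl, 2-fluoro-6-hydroxyphenyl and 3-ethynylphenyl caps differ at all in this assay, and at what concentration any of them would show an effect.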